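The source may hold more compounds than are shown below. What is called first, only, known or untested is meant among the compounds shown, and "the series" means these compounds.

Measured compounds in a functional assay on MDA-MB-231 cells (Homo sapiens) for antiproliferative activity, read by MTT assay, with a stated time of 72 h; on this read-out lower numbers stand for stronger inhibition and higher numbers for weaker inhibition:

Compound 1, `CC(=O)O[C@H]1CC[C@]2(C)[C@H](CC[C@@](C)(O)[C@H]2CC[C@@H]2C(C)=CC[C@H]3[C@H](CC[C@]3(C)O)C2(C)C)OC1(C)C`: compound 1 gives 38000 nM.
Compound 2, `CC1=CC[C@H]2[C@H](CC[C@]2(C)O)C(C)(C)[C@@H]1CC[C@H]1[C@]2(C)CC[C@H](OC(=O)CCC(=O)O)C(C)(C)O[C@H]2CC[C@@]1(C)O`: compound 2 gives 27900 nM.
Compound 3, `CC(=O)O[C@H]1CC[C@]2(C)[C@H](CC[C@@](C)(O)[C@H]2CC[C@@H]2C(C)=CC[C@@H]3C(C)=CC[C@@H]3C2(C)C)OC1(C)C`: compound 3 gives 39200 nM.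

Compound 4, `CC1=CC[C@H]2[C@@H]1CC=C(C)[C@@H](CC[C@H]1[C@]3(C)CC[C@H](OC(=O)CCC(=O)O)C(C)(C)O[C@H]3CC[C@@]1(C)O)C2(C)C`, has not yet been measured in this assay. Compound 2 arises from compound 1 by carboxymethyl in place of hydrogen on a saturated chain carbon bound to a carbonyl carbon, and that change made a 1.4-fold lower number from compound 1 to compound 2 (0.13 log units; within the scatter). Compound 4 arises from compound 3 by carboxymethyl in place of hydrogen on a saturated chain carbon bound to a carbonyl carbon, which is the same change at the same place; it occurs twice among these four compounds. How the core of compound 3 differs from the core of compound 1 is not broken down here; the values of compound 1 and compound 3 in this assay lie within the scatter of each other. Among the measured compounds shown here, with only one earlier instance of the change to draw on, the step from compound 3 to compound 4 is expected to be of about the same size, a 1.4-fold lower number from compound 3 to compound 4 (0.13 log units; within the scatter), and this expectation rests on the earlier instance, a 1.4-fold lower number from compound 1 to compound 2 (0.13 log units; within the scatter). Compound 4 is therefore estimated to give 29000 nM in this assay, with a likely range from 15000 nM to 60000 nM.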

Compound 4, half-maximal inhibitory concentration: 29600 nM
Compound 4: middle estimate off by 1.0-fold (0.01 log units), on the low side; measured number inside the range.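

In this assay, putting carboxymethyl in place of hydrogen on a saturated chain carbon bound to a carbonyl carbon gives a 1.3-fold lower number from compound 3 to compound 4 (0.12 log units; within the scatter). Set beside the earlier instance, the change carries from one core to the other with no visible difference in the size of the step: the same change on two cores in this assay, a 1.4-fold lower number (0.13 log units; within the scatter) from compound 1 to compound 2 and a 1.3-fold lower number (0.12 log units; within the scatter) from compound 3 to compound 4, 1.0-fold (0.01 log units) apart, within the scatter of two such steps This shows that the two steps agree and that neither core sets itself apart here, but since both steps lie within the scatter, it does not show that the change has a real effect on either core, and two cores cannot say how it would behave on a further core in this series.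

The compounds shown leave open what happens when the acetoxy group gives way to something other than ((2-carboxyethyl)carbonyl)oxy, such as an ester ending in an amine or one with a longer chain before its carboxylic acid. They also leave open whether any such group would move the number beyond the scatter, and whether it would do so equally on both cores.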